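Halogen Swap on the Urea Phenyl: Lipophilicity Expected Steady

The compounds below may be only part of what the source reports. "The series", "measured", "known", "first", "only" and "open" are said of these compounds alone.

Going by the values given here, compound 2 `O=C(Nc1ccc(Br)cc1)Nc1ccc(OC2=NS(=O)(=O)c3ccccc32)cc1` gives 3.64 in a physicochemical assay for lipophilicity (a higher number here means a more lipophilic compound, a lower number a more polar compound), the higher of the two numbers measured so far; compound 1 `O=C(Nc1ccccc1)Nc1ccc(OC2=NS(=O)(=O)c3ccccc32)cc1` gives 2.89. Among the compounds with values here, the single measured step, a number 0.75 log units higher from compound 1 to compound 2 (beyond the scatter), brought in a halogen where none stood. Compound 3 `O=C(Nc1ccc(OC2=NS(=O)(=O)c3ccccc32)cc1)Nc1ccccc1Cl` differs from compound 2 in that (2-chlorophenyl in place of 4-bromophenyl on an amide-type nitrogen), so one halogenated ring is exchanged for another, and that measured step bears on it only loosely. A step of a number 0.24 log units lower from compound 2 to compound 3 (within the scatter) is therefore expected, within the usual scatter. For compound 3 the estimate is 3.4, with a range from 3 to 3.8.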

Compound 3, partition coefficient: 3.55
Compound 3: the middle estimate sits 0.15 log units below what was measured; the measured number falls inside the stated range.
By their numbers in this assay, from the lowest: compound 1; then compounds 3 and 2 (each within the scatter of the next).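

In this assay, 2-chlorophenyl in place of 4-bromophenyl on the amide-type nitrogen gives a step within the scatter (a number 0.09 log units lower from compound 2 to compound 3 (within the scatter)), so this exchange leaves the number effectively unmoved. The step from the compound without a halogen gives a change beyond the scatter (a number 0.66 log units higher from compound 1 to compound 3 (beyond the scatter)), so a second halogenated compound stands clear of compound 1. Nothing available explains these numbers. From the compounds shown here alone, the halogen and its place change together from compound 2 to compound 3, so their separate contributions remain open. Also open, going by these compounds, is what an amine or a carboxylic acid on this ring would give.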